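Vinyl, propargyl, cyclopropyl and propyl side chains on a sugar core

The source may report more compounds than this note shows. Statements on the series, on what has been measured and on what is new or still open speak of the compounds shown alone.

Compound 1 `C=C[C@@H]1O[C@H](COCc2ccccc2)[C@@H](OCc2ccccc2)[C@H](OCc2ccccc2)[C@H]1O` carries a vinyl group on the shared core, and in a functional assay on HL-60 cells (Homo sapiens) for antiproliferative activity, read by MTT assay (a higher number here means a weaker inhibitor, a lower number a stronger inhibitor), compound 1 gives 11800 nM. Compound 2 `C#CC[C@@H]1O[C@H](COCc2ccccc2)[C@@H](OCc2ccccc2)[C@H](OCc2ccccc2)[C@H]1O` carries a propargyl group instead; in this assay compound 2 is reported as "not active" (no number reported), with no number attached. Compound 3 `O[C@@H]1[C@@H](OCc2ccccc2)[C@H](OCc2ccccc2)[C@@H](COCc2ccccc2)O[C@H]1CC1CC1` carries a cyclopropyl group on the same carbon. In this assay compound 3 is likewise reported as "not active" (no number reported), so no single number places it; it stands with compound 2 among the entries without a number, while compound 1 alone has a measured value, and that value is itself weak. Compound 4 `CCCC[C@@H]1O[C@H](COCc2ccccc2)[C@@H](OCc2ccccc2)[C@H](OCc2ccccc2)[C@H]1O` is the next member: propyl in place of cyclopropyl on a saturated chain carbon bound to a saturated ring carbon. Among the compounds with values here, no measured pair shows what such a change does, so no step beyond the scatter can be foreseen in this assay, in either direction. Given that compound 3 is reported as "not active" (no number reported), compound 4 is expected to be weak, with an estimated value of 30000 nM, plausibly anywhere between 8000 nM and 100000 nM.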

Compound 4, half-maximal inhibitory concentration: "not active" (no number reported)
Compound 4 has no reported number here, so the estimate cannot be set against anything.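

Compound 3 and compound 4 are both reported as not active in this assay, with no number attached, so no step can be read between them. From the compounds shown here alone, how cyclopropyl and propyl compare on the shared core stays open. No available evidence bears on this result.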